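Cytotoxicity on L6 cells: two benzoxazole amides and a pyridyl analogue

This account rests on a few compounds, and the source may have more. Where it says the series, first, only, none or still open, it means among the compounds named here.

Measured so far:
compound 1 `O=C(Nc1c(O)cccc1-c1nc2c(C(=O)O)cccc2o1)c1cccc(Cl)c1` – 143000 nM
compound 2 `O=C(Nc1ccccc1-c1nc2c(C(=O)O)cccc2o1)c1ccccc1` – 114000 nM

Both compounds carry the shared core of compound 1 and differ in the amide side and in a hydroxyl on the central ring. In an ADME assay on L6 cells (Rattus norvegicus) for cytotoxicity (on this read-out lower numbers stand for stronger inhibition and higher numbers for weaker inhibition), compound 1 gives 143000 nM. In this assay compound 2 gives 114000 nM. Compound 1 stands at one end of the two numbers shown, but compound 2 lies within the scatter of it, so the two cannot be separated on this read-out; both point to weak inhibition of cell growth.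

The next compound, compound 3 `O=C(Nc1c(O)cccc1-c1nc2c(C(=O)O)cccc2o1)c1ncccc1O`, keeps everything of compound 1 except the group on the carbonyl carbon: 3-hydroxypyridin-2-yl in place of 3-chlorophenyl on a carbonyl carbon. Going by the values given here, no step between two measured compounds covers this kind of change, so there is no measured precedent for its size. Given that compound 1 and compound 2 already sit close together despite differing on the amide side, no step beyond the scatter is expected from compound 1 to compound 3, and the estimate is a 1.1-fold higher number from compound 1 to compound 3 (0.05 log units; within the scatter). Compound 3 is expected to give about 160000 nM, with a range from 70000 nM to 350000 nM.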

Compound 3, half-maximal inhibitory concentration: 14200 nM
Compound 3: the middle estimate sits 11-fold (1.05 log units) above what was measured, and the stated range ends above it.
By their numbers in this assay, from the lowest: compound 3; then compounds 2 and 1 (each within the scatter of the next).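

Replacing 3-chlorophenyl with 3-hydroxypyridin-2-yl on a carbonyl carbon whose other neighbour is an amide-type nitrogen gives in this assay a 10-fold lower number from compound 1 to compound 3 (1.00 log units; beyond the scatter) and so moves the read-out beyond the scatter, towards stronger inhibition. Going by these compounds alone, this is the first change in one place, and it shows that the group on this carbonyl carbon can shift the read-out while the rest of compound 1 stays the same. The exchange alters several counted features together, namely a ring of carbon only for a ring with a hetero atom, the loss of chlorine and the arrival of hydrogen-bond donor and acceptor atoms, and nothing at hand links the step to any one of them.

Still open, going by these compounds, is whether the ring nitrogen or the hydroxyl accounts for the step, a question that 3-hydroxyphenyl and unsubstituted pyridin-2-yl on the same carbonyl carbon would separate. Also open, on these data alone, is how the read-out would respond at this position to a non-aromatic group such as a short alkyl amine or to a ring bearing a carboxylic acid.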